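Trading a sulfonyl arm for a diethylcarbamoyl group

A few compounds are considered here, and "the series" means these few. Any claim that something is new, unique, unknown or untested is made for them only; others in the source may bear on it.

Among the three compounds measured so far, compound 1 `O=C([C@@H]1CCCN(S(=O)(=O)c2ccc(S(=O)(=O)N3CC[C@@H](O)C3)cc2)C1)N1CCC(F)(F)CC1` gives the lowest number: in a functional assay on MIA PaCa-2 cells (Homo sapiens) for inhibition, read by MTT assay, with a stated time of 7 days (a higher number here means a weaker inhibitor, a lower number a stronger inhibitor), compound 1 gives 210 nM. Compound 2 `CCN(CC)S(=O)(=O)c1ccc(S(=O)(=O)N2CCC[C@@H](C(=O)N3CCC(O)CC3)C2)cc1` gives 870 nM, and compound 3 `CCN(CC)S(=O)(=O)c1ccc(S(=O)(=O)N2CCC[C@@H](C(=O)NC3CCOCC3)C2)cc1` gives 3770 nM, so compound 1 stands clearly ahead of both. Among the compounds with values here, the one change studied so far, a 4.3-fold higher number from compound 2 to compound 3 (0.64 log units; beyond the scatter), concerns the amide end of the core, and it is the only step available.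

Compound 4 `CCN(CC)C(=O)c1ccc(S(=O)(=O)N2CCC[C@@H](C(=O)N3CCC(F)(F)CC3)C2)cc1` differs from compound 1 at the other end: diethylcarbamoyl in place of (3-hydroxypyrrolidin-1-yl)sulfonyl on an aromatic carbon, the place being on an aromatic carbon of a six-membered aromatic ring of carbon only, para to a large group. Within the data shown here, no measured pair isolates this change. Among the measured compounds shown here, compound 2 carries a different aromatic substituent than compound 1, but it also carries a different amide, so the two values show only that the pair of changes together costs potency, not how much each contributes. With nothing bearing directly on the swap, a modest weakening is expected, with wide uncertainty, so that a 2.4-fold higher number from compound 1 to compound 4 (0.38 log units; beyond the scatter) is the estimated step. Compound 4 is therefore expected to give about 500 nM, within a range from 150 nM to 1800 nM.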

Compound 4, half-maximal inhibitory concentration: 70 nM
Estimate against measurement, compound 4: 7.1-fold (0.85 log units) above, and the stated range ends above it.
By their numbers in this assay, from the lowest: compound 4; then compound 1; then compound 2; then compound 3.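

Read in this assay, the swap of (3-hydroxypyrrolidin-1-yl)sulfonyl for diethylcarbamoyl gives a 3.0-fold lower number from compound 1 to compound 4 (0.48 log units; beyond the scatter), the first step at this place on the aromatic ring, since the only earlier step concerned the amide end of the core. With the 4,4-difluoropiperidine amide held constant, the step shows that the number at this position responds to the substituent and that the smaller diethylcarbamoyl group, with no ring, no hydrogen-bond donor and no defined stereocentre, gives the lower number, so none of those three features of the departing group is needed for potency at this level in this assay. No available evidence bears on why the number falls with this change.

The compounds shown leave open which part of the swap matters, as the single step changes the sulfonyl to a carbonyl and the hydroxypyrrolidine to a diethylamine together. They also leave open how this place would respond to a dimethylcarbamoyl group, a pyrrolidine-1-carbonyl group or a carboxylic acid, and whether the diethylcarbamoyl group would give a similar step beside another amide end.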